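Hexyl on the chain of compound 2

This account rests on a few compounds, and the source may have more. Where it says the series, first, only, none or still open, it means among the compounds named here.

In a functional assay on SW480 cells (Homo sapiens) for antiproliferative activity, read by MTT assay, with a stated time of 48 h (on this read-out lower numbers stand for stronger inhibition and higher numbers for weaker inhibition), compound 1 `CCCCC(CCO)n1cnc2c(Cl)ncnc21` gives > 50000 nM, which is a limit of the assay and not a number. Compound 2 `CCCCC(CCO)n1cnc2c(OC)ncnc21` gives > 50000 nM, which is also a limit. For the measured compounds named here, the series so far therefore stands at the limit of > 50000 nM in this assay, at which 2 of the 2 values shown sit, and compound 2 has no measured number of its own.

Compound 3 `CCCCCCCCCCC(CCO)n1cnc2c(OC)ncnc21` keeps the methoxy group of compound 2 and differs from it in one place: hexyl in place of hydrogen on a saturated chain carbon, five bonds along the chain from an aromatic nitrogen. This is hexyl in place of hydrogen on a saturated chain carbon, five bonds along the chain from an aromatic nitrogen.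

The expectation rests on the structural change alone because a step that the two limits leave unreadable from compound 1 to compound 2 gives no size to carry over. That step also concerns methoxy in place of chloro on an aromatic carbon, not the chain. A move toward stronger inhibition in this assay is expected, though of uncertain size, and a further limit remains possible. The expected step is an at least 2.5-fold lower number from compound 2 to compound 3 (0.39 log units; beyond the scatter). Compound 3 is estimated at 20000 nM, with an expected range from 5000 nM to 50000 nM.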

Compound 3, half-maximal inhibitory concentration: 8260 nM
The estimate for compound 3 lay 2.4-fold (0.38 log units) above the measured number, within the range that was stated.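

Hexyl in place of hydrogen on a saturated chain carbon, five bonds along the chain from an aromatic nitrogen, is the first change in this series with a readable effect in this assay, giving an at least 6.0-fold lower number from compound 2 to compound 3 (0.78 log units; beyond the scatter). Compound 2 gives > 50000 nM, which is a limit of the assay and not a number. For the compounds shown here, this makes the chain carbon the one place so far where a change has moved the read-out, and compound 3 the only compound with a measured number, while the step from compound 1 to compound 2 cannot be read and the other compounds stay at the limit: the limit of > 50000 nM in this assay, at which 2 of the 3 values shown sit.

With only hydrogen and hexyl compared at this place, the compounds shown do not tell whether the effect follows chain length, so a propyl group or a decyl group would be needed to show how the number changes with the length of the chain. They also leave open whether the effect of the hexyl group holds with chloro in place of methoxy on the aromatic carbon, and whether an amine can stand in for the hydroxyl at the end of the chain.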